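From thiophen-2-yl to thiophen-3-yl on the shared core

A few compounds are considered here, and "the series" means these few. Any claim that something is new, unique, unknown or untested is made for them only; others in the source may bear on it.

Measured values in a functional assay on the whole organism for inhibition, with Rattus norvegicus as the target (on this read-out higher numbers stand for weaker inhibition and lower numbers for stronger inhibition), are these:

Compound 1 `O=C1ON=C(c2cccs2)/C1=C/c1ccccc1` gives 4400 nM
Compound 2 `O=C1ON=C(c2cccs2)/C1=C/c1cccs1` gives 3700 nM

Among the measured compounds shown here, compound 2 has only one measured neighbour, and the gap to it is a 1.2-fold lower number from compound 1 to compound 2 (0.08 log units; within the scatter), which lies within the scatter. Neither compound can therefore be placed ahead of the other.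

Compound 3 `O=C1ON=C(c2cccs2)/C1=C/c1ccsc1` has not yet been measured. Its difference from compound 2 is thiophen-3-yl in place of thiophen-2-yl on a double-bonded chain carbon bound to a double-bonded ring carbon. The two have the same atoms, joined differently.

For the measured compounds named here, no measured compound carries thiophen-3-yl, so the evidence is indirect. Going by the values given here, one measured step bears on this change, made at the same place with thiophen-2-yl in place of phenyl. Since that step was only a 1.2-fold lower number from compound 1 to compound 2 (0.08 log units; within the scatter), no step beyond the scatter is expected in this assay in either direction. The expected step is a 1.0-fold higher number from compound 2 to compound 3 (0.01 log units; within the scatter) and nothing larger is anticipated. For compound 3 the estimated value is 3800 nM, with an expected range from 1800 nM to 8000 nM.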

Compound 3, half-maximal inhibitory concentration: 3000 nM
Estimate against measurement, compound 3: 1.3-fold (0.10 log units) above, and the stated range covers the measured number.
By their numbers in this assay, from the lowest: compounds 3, 2 and 1 (each within the scatter of the next).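

Joining the thiophene through a different ring carbon, with thiophen-3-yl in place of thiophen-2-yl on a double-bonded chain carbon bound to a double-bonded ring carbon, does not separate the two compounds in this assay (a 1.2-fold lower number from compound 2 to compound 3 (0.09 log units; within the scatter)). The comparison with phenyl at the same place gives the same reading (a 1.5-fold lower number from compound 1 to compound 3 (0.17 log units; within the scatter)), so phenyl, thiophen-2-yl and thiophen-3-yl cannot be told apart here, and none of the three compounds can be placed ahead of the others. No information is available that could explain this flat picture.

The compounds shown leave open whether this place accepts anything other than an unsubstituted aromatic ring: an amine, a carboxylic acid or a longer chain there might shift the number beyond the scatter, or might leave it where it is. They also leave open whether a phenyl ring carrying a methoxy group or a chlorine atom would stay as close to these three compounds as they stand to one another.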